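The source may report more compounds than this note shows. Statements on the series, on what has been measured and on what is new or still open speak of the compounds shown alone.

Measured so far in a functional assay on cells for antagonist activity at C-X-C chemokine receptor type 4 (Homo sapiens), read by fluorescence and calcium flux, with stated times of 25 min and 90 s; a lower number here means a stronger inhibitor, a higher number a weaker inhibitor:
compound 1 `c1ccc2c(c1)CN[C@@H](CN(CCCCN(Cc1ccncc1)Cc1ccncc1)[C@H]1CCCc3cccnc31)C2` gives 832 nM;
compound 2 `c1cncc(CNCCCCN(C[C@H]2Cc3ccccc3CN2)[C@H]2CCCc3cccnc32)c1` gives 15.3 nM;
compound 3 `c1ccc2c(c1)CN[C@@H](CN(CCCCNCc1ccncc1)[C@H]1CCCc3cccnc31)C2` gives 22.7 nM.

Compound 3 stands second highest of these three numbers in this assay. The nearest neighbour is seen in a 1.5-fold higher number from compound 2 to compound 3 (0.17 log units; within the scatter), a gap that lies within the scatter. The furthest is seen in a 37-fold lower number from compound 1 to compound 3 (1.56 log units; beyond the scatter), a large step in which a second (pyridin-4-yl)methyl group on an amine nitrogen was replaced by hydrogen.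

Compound 4 `c1ccc2c(c1)CN[C@@H](CN(CCCCNCC1CCCCC1)[C@H]1CCCc3cccnc31)C2` differs from compound 3 in one place: cyclohexyl in place of pyridin-4-yl on a saturated chain carbon bound to an amine nitrogen. Neither measured step makes this kind of change. The step of a 1.5-fold higher number from compound 2 to compound 3 (0.17 log units; within the scatter) only moved the ring nitrogen to another position and stayed within the scatter; the step of a 37-fold lower number from compound 1 to compound 3 (1.56 log units; beyond the scatter) removed a whole group rather than exchanging one ring for another. For the measured compounds named here, no measured step therefore bears directly on exchanging the aromatic ring with one hetero atom for a non-aromatic ring of carbon only, and the expectation is correspondingly uncertain; a modest weakening is expected. Compound 4 is estimated to give 60 nM in this assay, with a range from 15 nM to 300 nM. This estimate means an expected step of a 2.6-fold higher number from compound 3 to compound 4 (0.42 log units; beyond the scatter).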

Compound 4, half-maximal inhibitory concentration: 158 nM
Compound 4: the middle estimate sits 2.6-fold (0.42 log units) below what was measured, and the stated range covers the measured number.
By their numbers in this assay, from the lowest: compounds 2 and 3 (each within the scatter of the next); then compound 4; then compound 1.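

In this assay, exchanging an aromatic ring with a nitrogen for a ring of carbon only matters far more at this place than moving that nitrogen did, with a 7.0-fold higher number from compound 3 to compound 4 (0.84 log units; beyond the scatter) and a 10-fold higher number from compound 2 to compound 4 (1.01 log units; beyond the scatter) both beyond the scatter. Cyclohexyl has the same count of heavy atoms as pyridin-4-yl, so on a saturated chain carbon bound to an amine nitrogen, ring size alone does not set the number. No measurement shown explains why the number rises with this exchange.

The exchange removes the ring nitrogen and the aromatic ring together, so the compounds shown cannot tell which of the two accounts for the rise. A phenyl group, aromatic with carbon only, or a piperidin-4-yl group, non-aromatic with a ring nitrogen, at this place would separate them.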